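From furan-3-yl to 1,3-thiazol-2-yl on a shared core

A few compounds are considered here, and "the series" means these few. Any claim that something is new, unique, unknown or untested is made for them only; others in the source may bear on it.

The values below come from a functional assay on MCF7 cells (Homo sapiens) for inhibition, with a stated time of 96 h (a higher number here means a weaker inhibitor, a lower number a stronger inhibitor), and run as follows.
Compound 1 `COc1cc(C(=O)c2cn(-c3ccc(F)cc3)cc2-c2ccsc2)cc(OC)c1OC` gives 15 nM
Compound 2 `COc1cc(C(=O)c2cn(-c3ccc(F)cc3)cc2-c2ccco2)cc(OC)c1OC` gives 17 nM
Compound 3 `COc1cc(C(=O)c2cn(-c3ccc(F)cc3)cc2-c2ccoc2)cc(OC)c1OC` gives 15 nM

Compound 3 reads the same as compound 1, and compound 2 lies within the scatter of both. The next change puts 1,3-thiazol-2-yl in place of furan-3-yl on an aromatic carbon and gives compound 4 `COc1cc(C(=O)c2cn(-c3ccc(F)cc3)cc2-c2nccs2)cc(OC)c1OC` for testing. Three swaps at this place bear on it. They are no change at the digits printed from compound 1 to compound 3 (within the scatter) and a 1.1-fold lower number from compound 2 to compound 3 (0.05 log units; within the scatter) and a 1.1-fold higher number from compound 1 to compound 2 (0.05 log units; within the scatter) and all lie within the scatter. Within the data shown here, no measured compound carries a 1,3-thiazol-2-yl group, so the margin must stay wide. In this assay a small move towards a higher number, not beyond the scatter, is expected. The estimated step is a 1.5-fold higher number from compound 3 to compound 4 (0.17 log units; within the scatter) and so stays modest. For compound 4 the estimate is 22 nM with an expected range from 9 nM to 70 nM as its upper end.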

Compound 4, half-maximal inhibitory concentration: 22 nM
Beside the measured number, compound 4's estimate shows no gap at the digits printed; the measured number falls inside the stated range.
By their numbers in this assay, from the lowest: compounds 1, 3, 2 and 4 (each within the scatter of the next).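

Among these compounds, with 1,3-thiazol-2-yl, the ring at this position holds two hetero atoms, one of them a nitrogen, for the first time, yet in this assay the steps are a 1.5-fold higher number from compound 3 to compound 4 (0.17 log units; within the scatter) and a 1.3-fold higher number from compound 2 to compound 4 (0.11 log units; within the scatter) and a 1.5-fold higher number from compound 1 to compound 4 (0.17 log units; within the scatter) and all stay within the scatter. This position therefore accepts all four five-membered aromatic rings shown without a step beyond the scatter. No measured evidence here explains this result.

Only five-membered aromatic rings appear at this position. On these data alone, whether an amine, a carboxylic acid or a longer chain would keep the number at this level remains open.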